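The source may hold more compounds than are shown below. What is called first, only, known or untested is meant among the compounds shown, and "the series" means these compounds.

Of the compounds shown here, three have been measured so far in a physicochemical assay for solubility, using the shake flask method, in simulated intestinal fluid, measured as kinetic solubility, with a stated time of 2 h, at 25 degrees C, at pH 6.5; a lower number here means a less soluble compound, a higher number a more soluble compound. Compound 1 `COC(=O)c1nc(C)c2c(c1N)C(=O)N(Cc1ccccc1)C2=O` gives 7400 nM and compound 2 `Cc1noc(-c2nc(C)c3c(c2N)C(=O)N(Cc2ccc(Oc4ccc(F)cc4)cc2)C3=O)n1` gives 23800 nM. Compound 3 `Cc1noc(-c2nc(C)c3c(c2N)C(=O)N(Cc2ccc(Cl)cc2)C3=O)n1` stands at a limit of the assay, < 5000 nM, and has no number of its own.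

Compound 4 `Cc1noc(-c2nc(C)c3c(c2N)C(=O)N(Cc2ccccc2F)C3=O)n1` keeps the shared core of compound 3 and changes only the group on the saturated chain carbon bound to an amide-type nitrogen in a ring: 4-chlorobenzyl gives way to 2-fluorobenzyl (2-fluorophenyl in place of 4-chlorophenyl on a saturated chain carbon bound to an amide-type nitrogen in a ring).

Among the compounds with values here, only one measured step touches this part of the structure. Chloro replaced 4-fluorophenoxy in the step of an at least 4.7-fold lower number from compound 2 to compound 3 (0.67 log units; beyond the scatter), which lies beyond the scatter. Within the data shown here, that change removed far more of the group than the present swap does, since the exchange here leaves the heavy-atom count unchanged, and no measured step isolates a change of halogen or its position. A step of similar size is therefore not expected, and the most likely outcome is a small one with no firm direction.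

The step is estimated as an at least 1.2-fold higher number from compound 3 to compound 4 (0.07 log units; that floor lies within the scatter) and may well stay within the scatter. For compound 4 the expected value is 6000 nM with an estimated range of 2500 nM to 15000 nM and the assay may again report only a limit.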

Compound 4, solubility: < 5000 nM
Compound 4: only a limit was reported; the forecaster's own chance of this, stated with the estimate: 50%; at least 1.2-fold (0.07 log units) between middle value and limit.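

In this assay compound 4 returns the limit < 5000 nM and no number of its own. Compound 3 also stands at a limit, so the step from compound 3 to compound 4 cannot be read: the limit of < 5000 nM in this assay, at which 2 of the 4 values shown sit. The compounds shown leave open whether 4-chlorobenzyl and 2-fluorobenzyl differ at all in solubility, and by how much.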